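Replacing a phenyl-bearing side chain with an open chain

This account rests on a few compounds, and the source may have more. Where it says the series, first, only, none or still open, it means among the compounds named here.

Measured so far in a functional assay on DU-145 cells (Homo sapiens) for cytotoxicity, read by MTT assay; on this read-out lower numbers stand for stronger inhibition and higher numbers for weaker inhibition:
- compound 1 `CCCCC(O)CC(=O)O[C@H](CC=C(C)C)C1=CC(=O)c2c(O)ccc(O)c2C1=O` gives 45300 nM
- compound 2 `CC(C)=CC[C@@H](OC(=O)CC(O)c1ccccc1)C1=CC(=O)c2c(O)ccc(O)c2C1=O` gives 17000 nM

Compound 2 holds the lower of these two numbers. Compound 3 `CC[C@@](C)(O)CC(=O)O[C@H](CC=C(C)C)C1=CC(=O)c2c(O)ccc(O)c2C1=O` carries 1-hydroxy-1-methylpropyl in place of hydroxy(phenyl)methyl on a saturated chain carbon bound to a carbonyl carbon. Among the measured compounds shown here, one measured step bears on this change, the modest swap of butyl for phenyl (a 2.7-fold lower number from compound 1 to compound 2 (0.43 log units; beyond the scatter)). Compound 3 loses the phenyl and has no ring in that group, like compound 1 (45300 nM), so a step of similar modest size in the opposite direction, towards a higher number in this assay, is expected. A single step is thin support, so the range stays wide. The expected step is a 2.2-fold higher number from compound 2 to compound 3 (0.35 log units; beyond the scatter) on this estimate. For compound 3 the estimated value is 38000 nM (expected range 14000 nM to 90000 nM).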

Compound 3, half-maximal inhibitory concentration: 12700 nM
The estimate for compound 3 lay 3.0-fold (0.48 log units) above the measured number, outside the stated range (below it).
By their numbers in this assay, from the lowest: compounds 3 and 2 (each within the scatter of the next); then compound 1.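

In this assay, putting 1-hydroxy-1-methylpropyl in place of hydroxy(phenyl)methyl gives a 1.3-fold lower number from compound 2 to compound 3 (0.13 log units; within the scatter) and so leaves the two compounds indistinguishable, which shows that a phenyl ring on this saturated chain carbon bound to a carbonyl carbon is not required to reach this level. The ring-free group of compound 1 therefore does not speak for all ring-free groups: exchanging its 1-hydroxypentyl for 1-hydroxy-1-methylpropyl gives a 3.6-fold lower number from compound 1 to compound 3 (0.55 log units; beyond the scatter) and makes compound 1 the exception to any link between losing the ring and a higher number. Nothing available here explains these differences.

Still open, going by these compounds, is whether the opposite configuration of the defined stereocentre in 1-hydroxy-1-methylpropyl would give a different number. On these data alone, it is equally open how this position would respond to an amine or a carboxylic acid in place of the hydroxy group.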